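This account rests on a few compounds, and the source may have more. Where it says the series, first, only, none or still open, it means among the compounds named here.

In a functional assay on COLO 205 cells (Homo sapiens) for cytotoxicity, read by MTT assay, with a stated time of 48 h (on this read-out higher numbers stand for weaker inhibition and lower numbers for stronger inhibition), three compounds that differ only in the group on one nitrogen have been read so far. Compound 1 `Fc1ccc(Nc2nc(-c3cccc(F)c3)nc3ccc(F)cc23)cc1` gives > 50000 nM, which is a limit of the assay. Compound 2 `Fc1cccc(-c2nc(Nc3ccccc3Cl)c3cc(F)ccc3n2)c1` gives > 50000 nM, again a limit. Compound 3 `Oc1cccc(Nc2nc(-c3cccc(F)c3)nc3ccc(F)cc23)c1` gives > 50000 nM, also a limit. Compound 3 thus stands at the limit of > 50000 nM in this assay, at which 3 of the 3 values shown sit.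

The next compound, compound 4 `Cc1ccccc1Nc1nc(-c2cccc(F)c2)nc2ccc(F)cc12`, departs from compound 3 in that same place: 2-methylphenyl in place of 3-hydroxyphenyl on a nitrogen on an aromatic ring. It carries 2-methylphenyl in place of 3-hydroxyphenyl on a nitrogen on an aromatic ring.

Three measured exchanges at this place bear on the change: a step that the two limits leave unreadable from compound 1 to compound 2, then a step that the two limits leave unreadable from compound 1 to compound 3, and finally a step that the two limits leave unreadable from compound 2 to compound 3. None of them has a readable size, and none of the three groups has yielded a number, so neither a direction nor a step beyond the scatter is expected. The expected change, as estimated, is a number no higher from compound 3 to compound 4 (the limit leaves the size open). In this assay, compound 4 is estimated at 50000 nM, with an expected range from 20000 nM to 100000 nM.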

Compound 4, half-maximal inhibitory concentration: > 50000 nM
Compound 4: no number, only a limit (the forecaster's own chance of this, stated with the estimate: 85%); the middle value sits exactly at the limit.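

No step between compound 4 and compound 1, compound 2 or compound 3 can be read, as all four values are the same limit: the limit of > 50000 nM in this assay, at which 4 of the 4 values shown sit.

The compounds shown leave open how strongly any of the four acts on these cells, and whether the group on this nitrogen changes the read-out at all.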